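This account rests on a few compounds, and the source may have more. Where it says the series, first, only, none or still open, it means among the compounds named here.

The measured compounds, with their results in a functional assay on M21 cells (Homo sapiens) for antiproliferative activity, read by sulforhodamine B assay, with a stated time of 48 h; on this read-out higher numbers stand for weaker inhibition and lower numbers for stronger inhibition:

Compound 1, `CCCC(=O)Nc1ccc(S(=O)(=O)Oc2ccccc2C(C)C)cc1`: 6100 nM
Compound 2, `CCCC(=O)Nc1ccc(S(=O)(=O)Oc2ccccc2I)cc1`: 9000 nM
Compound 3, `CCCCCNC(=O)Nc1ccc(S(=O)(=O)Oc2ccccc2C(C)C)cc1`: 4600 nM

All three share a sulfonate ester linking two aromatic rings, and they differ at two places. Compound 2 is derived from compound 1 by one change, (iodo in place of isopropyl on an aromatic carbon), and this gave a 1.5-fold higher number from compound 1 to compound 2 (0.17 log units; within the scatter). Compound 3 is derived from compound 1 by a different change, at the other end of the molecule, (pentylamino in place of propyl on a carbonyl carbon), and this gave a 1.3-fold lower number from compound 1 to compound 3 (0.12 log units; within the scatter). Neither step moves the number beyond what repeated measurements of this kind commonly show, so the three compounds cannot be ranked against one another with any confidence.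

Compound 4, `CCCCCNC(=O)Nc1ccc(S(=O)(=O)Oc2ccccc2I)cc1`, has not yet been measured. It stands to compound 3 as compound 2 stands to compound 1: the difference is iodo in place of isopropyl on an aromatic carbon. Since the surroundings of the exchanged group are described in the same words for both pairs, this is the same change, seen a second time on a core that differs from the first only in the way just described.

For the measured compounds named here, the expectation for compound 4 therefore rests on the single earlier instance of this change. The step from compound 3 to compound 4 is expected to be a 1.5-fold higher number from compound 3 to compound 4 (0.18 log units; within the scatter), in line with the step seen from compound 1 to compound 2, a 1.5-fold higher number from compound 1 to compound 2 (0.17 log units; within the scatter). On that basis compound 4 is estimated to give about 7000 nM in this assay, with a plausible range from 3500 nM to 14000 nM.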

Compound 4, half-maximal inhibitory concentration: 5900 nM
Beside the measured number, compound 4's estimate is 1.2-fold (0.07 log units) above it; low and high end bracket the measured number.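

In this assay, putting iodo in place of isopropyl on the core of compound 3 gave a 1.3-fold higher number from compound 3 to compound 4 (0.11 log units; within the scatter), and this step agrees with the one seen earlier for the same change on the core of compound 1: the same change on two cores in this assay, a 1.5-fold higher number (0.17 log units; within the scatter) from compound 1 to compound 2 and a 1.3-fold higher number (0.11 log units; within the scatter) from compound 3 to compound 4, 1.2-fold (0.06 log units) apart, within the scatter of two such steps. The other change, pentylamino in place of propyl on a carbonyl carbon, gave a 1.5-fold lower number from compound 2 to compound 4 (0.18 log units; within the scatter) and likewise agrees with its earlier instance: the same change on two cores in this assay, a 1.3-fold lower number (0.12 log units; within the scatter) from compound 1 to compound 3 and a 1.5-fold lower number (0.18 log units; within the scatter) from compound 2 to compound 4, 1.2-fold (0.06 log units) apart, within the scatter of two such steps. So neither change behaved differently on the second core, but every step here lies within the scatter, which means the agreement is between small steps, and it does not show that either change truly alters the activity or that a change with a clear effect would carry over in the same way.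

The compounds shown leave open whether another group on that aromatic carbon, such as methoxy or a carboxylic acid, or another group on the carbonyl carbon, such as a longer chain or an amine carrying a ring, would move the number beyond the scatter. For the compounds shown here, they also leave open whether such a larger step would repeat from one core to another, since only two cores and two changes are seen here.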